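This account rests on a few compounds, and the source may have more. Where it says the series, first, only, none or still open, it means among the compounds named here.

Compound 1 `CN1CCN(CCCOc2cccc3nc(Nc4ccc(F)c(F)c4)ccc23)CC1` gives, in a functional assay on MCF7 cells (Homo sapiens) for inhibition, read by sulforhodamine B assay, with a stated time of 48 h (on this read-out higher numbers stand for weaker inhibition of growth and lower numbers for stronger inhibition of growth), a value of 3330 nM. Compound 2 `CN1CCN(CCCOc2cccc3nc(Nc4cc(Cl)cc(Cl)c4)ccc23)CC1` gives in this assay a value of 1380 nM. For the measured compounds named here, the only step between measured compounds, a 2.4-fold lower number from compound 1 to compound 2 (0.38 log units; beyond the scatter), comes from exchanging the halogen pattern on the aryl group attached to the nitrogen. Going by the values given here, of the two numbers so far, compound 2 therefore has the lower one, and compound 1 sits a modest step above it.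

Compound 3 `CN1CCN(CCCOc2cccc3nc(Nc4cccc(Cl)c4)ccc23)CC1` differs from compound 2 in one place: hydrogen in place of chloro on an aromatic carbon. Among the compounds with values here, no measured step removes a single halogen from this aryl group, so the only guide is the step from compound 1 to compound 2, which shows that changing the halogens on that ring moved the number by a modest amount. Taking away one of the two chloro groups is expected to shift compound 3 towards a somewhat higher number in this assay than compound 2, by a 1.6-fold higher number from compound 2 to compound 3 (0.20 log units; within the scatter), though a result within the scatter would not be surprising. Compound 3 is therefore expected to give about 2200 nM, in a range from 1000 nM to 5000 nM.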

Compound 3, concentration for 50% growth inhibition: 1570 nM
For compound 3 the middle estimate is 1.4-fold (0.15 log units) above the measured one; the range from low to high includes it.
By their numbers in this assay, from the lowest: compounds 2 and 3 (each within the scatter of the next); then compound 1.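

In this assay the loss of one chloro group from the 3,5-dichlorophenyl group gives a 1.1-fold higher number from compound 2 to compound 3 (0.06 log units; within the scatter) and so leaves the read-out within the scatter, which means that this aromatic carbon tolerates hydrogen in place of chloro without a measurable difference here. The 3-chlorophenyl group still differs from the 3,4-difluorophenyl group, with a 2.1-fold lower number from compound 1 to compound 3 (0.33 log units; beyond the scatter) and thus a modest step beyond the scatter, so the gap first seen with two chloro groups is also present with only one. Nothing measured here explains why the second chloro group makes no measurable difference.

The compounds shown leave open whether other groups on this aromatic carbon, such as methoxy, trifluoromethyl or an amine, would also stay within the scatter of hydrogen and chloro. They also leave open how an aryl group with a single fluoro group would compare with the 3-chlorophenyl group, and whether removing the remaining chloro group to give an unsubstituted phenyl group would change the read-out.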